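One Flipped Stereocentre in a Cytotoxicity Series

The compounds below may be only part of what the source reports. "The series", "measured", "known", "first", "only" and "open" are said of these compounds alone.

Within the data shown here, in a functional assay on A549 cells (Homo sapiens) for cytotoxicity, read by MTT assay (a higher number here means a weaker inhibitor, a lower number a stronger inhibitor), compound 2 (`COC(=O)C[C@H]1C[C@@H](O)[C@@H](C)[C@@H](c2ccc(F)cc2)N1`) gives 26600 nM, the higher of the two numbers so far and so the weaker inhibitor, while compound 1 (`COC(=O)C[C@H]1C[C@H](O)[C@@H](C)[C@@H](c2ccc(OC)cc2)N1`) gives 5400 nM. Compound 3 (`COC(=O)C[C@H]1C[C@H](O)[C@@H](C)[C@@H](c2ccc(F)cc2)N1`) is not yet measured. Its difference from compound 2 is this: the two compounds have the same atoms and bonds and differ only in configuration as drawn: 1 of 4 stereo elements differ; a stereocentre at a saturated ring carbon is drawn R in compound 2 and S in compound 3. Among the measured compounds shown here, no measured pair shows what such a change does on its own, so any forecast is loose. With compound 1 at 5400 nM as the only other reference, a modest move toward a lower number is expected, near the edge of the usual scatter in this assay. The estimated change is a 1.9-fold lower number from compound 2 to compound 3 (0.28 log units; within the scatter). For compound 3 the expected value is 14000 nM, within an estimated range of 5000 nM to 40000 nM.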

Compound 3, half-maximal inhibitory concentration: 17200 nM
Estimate against measurement, compound 3: 1.2-fold (0.09 log units) below, within the range that was stated.
By their numbers in this assay, from the lowest: compound 1; then compounds 3 and 2 (each within the scatter of the next).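

At this saturated ring carbon, a stereocentre drawn S rather than R gives a 1.5-fold lower number from compound 2 to compound 3 (0.19 log units; within the scatter), so this single change stays inside the noise of the assay. Compounds 1 and 2 differ in two places at once, whereas fluoro in place of methoxy on an aromatic carbon can now be read alone, giving a 3.2-fold higher number from compound 1 to compound 3 (0.50 log units; beyond the scatter). The stereocentre reading rests on one point: the fact that compounds 2 and 3 differ only in the configuration as drawn.

From the compounds shown here alone, whether a chloro group or an amine on the aromatic carbon would give a lower number remains open. So does the effect of the same stereocentre change with methoxy in place of fluoro.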